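The compounds below may be only part of what the source reports. "The series", "measured", "known", "first", "only" and "open" are said of these compounds alone.

- compound 1 `C[C@@H](N[C@H]1CCN(c2ccc(S(=O)(=O)NCC(=O)O)cc2)C1)c1cccc2ccccc12`: > 12 h
- compound 2 `C[C@@H](N[C@H]1CCN(c2ccc(C(=O)NC(CO)(CO)CO)cc2)C1)c1cccc2ccccc12`: > 12 h
- compound 3 `C[C@@H](N[C@H]1CCN(c2ccc(C(=O)NCCCCNC(CO)(CO)CO)cc2)C1)c1cccc2ccccc12`: 8 h

Among the measured compounds shown here, in an ADME assay on Caecum (Rattus norvegicus, strain Sprague-Dawley) for metabolic stability, read by LC-MS, tested at 10 uM (on this read-out lower numbers stand for a shorter-lived compound and higher numbers for a longer-lived compound), compound 3 gives 8 h, the only true number in this small set. The value of compound 1 is a limit of the assay, not a number. The value of compound 2 is likewise a limit. Together they form (the limit of > 12 h in this assay, at which 2 of the 3 values shown sit).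

Compound 4 `C[C@@H](N[C@H]1CCN(c2ccc(C(=O)N[C@H](CCCCN)C(=O)O)cc2)C1)c1cccc2ccccc12` carries 5-amino-1-carboxypentyl in place of 4-((2-hydroxy-1,1-bis(hydroxymethyl)ethyl)amino)butyl on the amide-type nitrogen: 5-amino-1-carboxypentyl in place of 4-((2-hydroxy-1,1-bis(hydroxymethyl)ethyl)amino)butyl on an amide-type nitrogen.

The most relevant measured change, made on that same nitrogen, is an at least 1.5-fold lower number from compound 2 to compound 3 (0.17 log units; that floor lies within the scatter), and that floor lies within the usual scatter. The other change, a step that the two limits leave unreadable from compound 1 to compound 2, offers no usable size. Neither step therefore supports a clear shift in either direction, so no change beyond the scatter is expected in this assay. The expected step is a 1.3-fold higher number from compound 3 to compound 4 (0.10 log units; within the scatter). The estimated half-life of compound 4 is 10 h, with an expected range from 5 h to 18 h.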

Compound 4, half-life: 4.3 h
The estimate for compound 4 lay 2.3-fold (0.37 log units) above the measured number, and the stated range ends above it.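

In this assay, 5-amino-1-carboxypentyl in place of 4-((2-hydroxy-1,1-bis(hydroxymethyl)ethyl)amino)butyl on the amide-type nitrogen gives a 1.9-fold lower number from compound 3 to compound 4 (0.27 log units; within the scatter), so this swap alone cannot be told apart from repeat-measurement noise. Set against 2-hydroxy-1,1-bis(hydroxymethyl)ethyl on that same nitrogen, the new group gives an at least 2.7-fold lower number from compound 2 to compound 4 (0.44 log units; beyond the scatter), the first readable step on this nitrogen to clear the scatter, and the change on the aromatic carbon from (carboxymethyl)sulfamoyl gives an at least 2.7-fold lower number from compound 1 to compound 4 (0.44 log units; beyond the scatter). Both of these sizes are only floors, because compounds 1 and 2 each stand at a limit of the assay: the limit of > 12 h in this assay, at which 2 of the 4 values shown sit.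

The compounds shown leave open whether the lower half-life goes with the amine or with the carboxylic acid of the new group, and a chain carrying only one of the two would separate them. Also open, as far as these compounds go, is how the half-life would respond to a longer chain between the amide nitrogen and that amine.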